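The compounds below may be only part of what the source reports. "The series", "measured", "known", "first", "only" and "open" are said of these compounds alone.

Compound 1 `c1coc(-c2ccccc2NCC2=NCCN2)c1` and compound 2 `Cc1ccc(-c2ccccc2NCC2=NCCN2)o1` share a core and are both measured in a functional assay for activation of Alpha-1A adrenergic receptor (Homo sapiens), read by calcium flux; a lower number here means that less compound is needed, a higher number that more compound is needed for the effect. Within the data shown here, there compound 1 gives 0.468 nM, and compound 2 gives 2.69 nM, the highest of the two numbers; the only recorded step, a 5.7-fold higher number from compound 1 to compound 2 (0.76 log units; beyond the scatter), concerns a methyl in place of hydrogen. Compound 3 `CCO/N=C(\C)c1ccccc1NCC1=NCCN1` is not yet measured. It differs from compound 2 by a group of 6 heavy atoms (4 carbon, 1 nitrogen, 1 oxygen; no ring) in place of a group of 6 heavy atoms (5 carbon, 1 oxygen; one five-membered aromatic ring with 1 hetero atom), on an aromatic carbon. Among the measured compounds shown here, no measured step covers such an exchange, so the estimate leans on the two values alone. A moderate rise is expected, a 3.0-fold higher number from compound 2 to compound 3 (0.47 log units; beyond the scatter), giving compound 3 an estimated 8 nM, with a range from 1.5 nM to 40 nM.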

Compound 3, half-maximal effective concentration: 52.5 nM
Compound 3: the middle estimate sits 6.6-fold (0.82 log units) below what was measured; measured number above the stated range.
By their numbers in this assay, from the lowest: compound 1; then compound 2; then compound 3.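

In this assay, this position on the six-membered aromatic ring of carbon only responds far more strongly to losing the five-membered aromatic ring than to adding a methyl to it. Swapping 5-methylfuran-2-yl for the open-chain group of the same heavy-atom count gives a 20-fold higher number from compound 2 to compound 3 (1.29 log units; beyond the scatter), and the total change is a 110-fold higher number from compound 1 to compound 3 (2.05 log units; beyond the scatter). So equal size alone does not preserve the low number here. No available evidence explains this rise. Still open, going by these compounds, is whether a phenyl or thienyl ring here would keep the low number of compound 1.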